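Swapping the thiazolylamino group for methylpiperazine

The source may hold more compounds than are shown below. What is called first, only, known or untested is meant among the compounds shown, and "the series" means these compounds.

Measured in a functional assay on KB cells (Homo sapiens) for cytotoxicity, read by MTT assay, with a stated time of 3 days; on this read-out lower numbers stand for stronger inhibition and higher numbers for weaker inhibition:
- compound 1 `CNc1nc(SCc2nc3ccccc3[nH]2)nc(-c2ccccc2)c1C#N`: 2.7 nM
- compound 2 `N#Cc1c(Nc2nccs2)nc(SCc2nc3ccccc3[nH]2)nc1-c1ccccc1`: 14.7 nM

Compound 2, at 14.7 nM, holds the higher of the two numbers, so it is the weaker inhibitor of the pair. Compound 3 `CN1CCN(c2nc(SCc3nc4ccccc4[nH]3)nc(-c3ccccc3)c2C#N)CC1` changes the same substituent: 4-methylpiperazin-1-yl in place of (1,3-thiazol-2-yl)amino on an aromatic carbon. Among the measured compounds shown here, only one measured step bears on this, a 5.4-fold higher number from compound 1 to compound 2 (0.74 log units; beyond the scatter), a modest change made when 1,3-thiazol-2-yl replaced methyl in the group that now leaves. One step is thin evidence, and the entering ring is new, so only a small move towards a lower number is expected in this assay. The expected change is a 1.8-fold lower number from compound 2 to compound 3 (0.26 log units; within the scatter). For compound 3 the estimate is 8 nM, with an expected range of 1.5 nM to 40 nM.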

Compound 3, half-maximal inhibitory concentration: 2.7 nM
Compound 3: the middle estimate sits 3.0-fold (0.47 log units) above what was measured, within the range that was stated.
By their numbers in this assay, from the lowest: compounds 1 and 3 (each within the scatter of the next); then compound 2.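

Putting 4-methylpiperazin-1-yl in place of (1,3-thiazol-2-yl)amino gives a 5.4-fold lower number from compound 2 to compound 3 (0.74 log units; beyond the scatter) in this assay and so shows that this position accepts a non-aromatic ring. That ring has no hydrogen-bond donor, so among these compounds a donor at this position is not required for a low number. Replacing methylamino with the same ring gives no change at the digits printed from compound 1 to compound 3 (within the scatter) and so the small and the larger group cannot be told apart here.

As far as these compounds go, whether morpholine or an unsubstituted piperazine would behave alike stays open. Nothing available explains these steps.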